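The source may report more compounds than this note shows. Statements on the series, on what has been measured and on what is new or still open speak of the compounds shown alone.

Working notes on the series.

Compound 1 `NC(=O)c1c(NC(=O)c2ccccc2F)sc2c1CCN(C(=S)Nc1ccccc1Cl)C2` and compound 3 `NC(=O)c1c(NC(=O)c2ccccc2F)sc2c1CCN(C(=S)Nc1cc(C(F)(F)F)cc(C(F)(F)F)c1)C2` share a thiophene-fused core but carry different groups on the thiourea nitrogen; the difference between the two cores is not broken down here. In a functional assay on HeLa cells (Homo sapiens) for antiproliferative activity, with a stated time of 24 h (on this read-out lower numbers stand for stronger inhibition and higher numbers for weaker inhibition), compound 1 gives 19400 nM, and compound 3 gives 28000 nM; these two values lie within the scatter of each other, so no order between them is claimed.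

Compound 2 `NC(=O)c1c(NC(=O)c2ccc(C(F)(F)F)cc2)sc2c1CCN(C(=S)Nc1ccccc1Cl)C2` is compound 1 with 4-(trifluoromethyl)phenyl in place of 2-fluorophenyl on a carbonyl carbon. In this assay compound 2 gives 44000 nM, which is a 2.3-fold higher number from compound 1 to compound 2 (0.36 log units; beyond the scatter).

Compound 4 `NC(=O)c1c(NC(=O)c2ccc(C(F)(F)F)cc2)sc2c1CCN(C(=S)Nc1cc(C(F)(F)F)cc(C(F)(F)F)c1)C2` is not yet measured. It is compound 3 with 4-(trifluoromethyl)phenyl in place of 2-fluorophenyl on a carbonyl carbon; the place line matches the earlier change word for word, so this is the same change seen once before, from compound 1 to compound 2. Going by the values given here, only that single pair supports it, so the expectation is tentative. On the strength of the step for compound 2, a 2.3-fold higher number from compound 1 to compound 2 (0.36 log units; beyond the scatter), the expected step in this assay from compound 3 to compound 4 is a 2.2-fold higher number from compound 3 to compound 4 (0.35 log units; beyond the scatter), of about the same size. Compound 4 is accordingly estimated at 62000 nM, with a plausible range from 26000 nM to 150000 nM.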

Compound 4, half-maximal inhibitory concentration: 49000 nM
For compound 4 the middle estimate is 1.3-fold (0.10 log units) above the measured one; the measured number falls inside the stated range.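

In this assay, placing 4-(trifluoromethyl)phenyl for 2-fluorophenyl on a carbonyl carbon of the core of compound 3 gives a 1.8-fold higher number from compound 3 to compound 4 (0.24 log units; within the scatter), so this pair alone does not separate the two compounds. Set beside the earlier step on the core of compound 1, the size of the change cannot be told apart between the two cores: the same change on two cores in this assay, a 2.3-fold higher number (0.36 log units; beyond the scatter) from compound 1 to compound 2 and a 1.8-fold higher number (0.24 log units; within the scatter) from compound 3 to compound 4, 1.3-fold (0.11 log units) apart, within the scatter of two such steps. Going by these compounds alone, this fits a change that carries over between these two cores at a similar modest size, but it rests on only two pairs, only one of which lies beyond the scatter, and it does not show that the change would carry over to any further core.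

The compounds shown carry only these two substituted phenyl groups on the carbonyl carbon, so it remains open how an amine, a carboxylic acid or a longer alkyl chain would behave at that place. From the compounds shown here alone, whether the two steps would stay alike on a thiourea nitrogen carrying an aliphatic amine also remains open.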